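The source may report more compounds than this note shows. Statements on the series, on what has been measured and on what is new or still open speak of the compounds shown alone.

In an ADME assay on MRC5 cells (Homo sapiens) for cytotoxicity (a lower number here means that less compound is tolerated, a higher number that more compound is tolerated), the measured compounds are:

compound 1 `Cc1cn([C@@H]2C[C@H](O)[C@@H](CNC(=S)Nc3ccc(OCc4ccccc4)cc3)O2)c(=O)[nH]c1=O`: > 50000 nM (a limit)
compound 2 `Cc1ccc2nc(-c3ccc(NC(=O)NC[C@H]4O[C@H](n5cc(C)c(=O)[nH]c5=O)C[C@@H]4O)cc3)sc2c1`: > 50000 nM (a limit)

Neither entry is a number, and the record so far is the limit of > 50000 nM in this assay, at which 2 of the 2 values shown sit. Compound 2 therefore stands only at a limit, given as > 50000 nM.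

Compound 3 `Cc1cn([C@@H]2C[C@H](O)[C@@H](CNC(=O)Nc3ccc(OCc4ccc(Cl)cc4)cc3)O2)c(=O)[nH]c1=O` has not yet been measured. It departs from compound 2 by one replacement: (4-chlorobenzyl)oxy in place of 6-methyl-1,3-benzothiazol-2-yl on an aromatic carbon. In words, (4-chlorobenzyl)oxy takes the place of 6-methyl-1,3-benzothiazol-2-yl on an aromatic carbon of a six-membered aromatic ring of carbon only, para to a large group.

Going by the values given here, no measured pair shows what a change of this kind does in this assay. The expectation therefore rests on compound 2 with its limit of > 50000 nM, and no step beyond the scatter is foreseen in either direction. The expected outcome is a number no higher from compound 2 to compound 3 (the limit leaves the size open). For compound 3 the estimated value is 50000 nM, with an expected range from 25000 nM to 100000 nM.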

Compound 3, half-maximal cytotoxic concentration: > 50000 nM
Compound 3 ended at the assay's limit; the forecaster's own chance of this, stated with the estimate: 75%; the middle value sits exactly at the limit.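

In this assay compound 3 gives > 50000 nM and this is a limit of the assay, not a number. Compound 2 also stands at a limit, so no step can be read between compound 2 and compound 3. The compounds shown leave open what concentration of any of them would prove half-maximally cytotoxic, and all that can be stated is this: the limit of > 50000 nM in this assay, at which 3 of the 3 values shown sit.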